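This account rests on a few compounds, and the source may have more. Where it says the series, first, only, none or still open, it means among the compounds named here.

Measured so far, cytotoxicity read-out:

Compound 1, `COc1ccc(Nc2nc3ccccc3nc2S(=O)(=O)c2ccccc2)cc1`, gives 2420 nM.
Compound 2, `COc1ccc(Nc2nc3ccccc3nc2S(=O)(=O)c2ccc(OC)cc2)cc1`, gives 29100 nM.
Compound 3, `COc1ccc(S(=O)(=O)c2nc3ccccc3nc2Nc2cc(OC)cc(OC)c2)cc1`, gives 13400 nM.

All three were run in a functional assay on HCT-116 cells (Homo sapiens) for cytotoxicity, read by MTT assay, with a stated time of 72 h; on this read-out higher numbers stand for weaker inhibition and lower numbers for stronger inhibition. The step from compound 1 to compound 2 is methoxy in place of hydrogen on an aromatic carbon; it made a 12-fold higher number from compound 1 to compound 2 (1.08 log units; beyond the scatter). The step from compound 2 to compound 3 is a change on the other aryl group and gave a 2.2-fold lower number from compound 2 to compound 3 (0.34 log units; beyond the scatter). Compound 3 stands second highest of the three numbers; the difference between the core of compound 1 and the core of compound 3 is not broken down here.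

Compound 4, `COc1ccc(S(=O)(=O)c2nc3ccccc3nc2Nc2cc(OC)c(OC)c(OC)c2)cc1`, is not yet measured. Relative to compound 3 the change is methoxy in place of hydrogen on an aromatic carbon. Within the data shown here, this is the same kind of change as the one from compound 1 to compound 2, made on the same series once, but not the same change: there the entering methoxy sat para to a large group only, whereas here it sits ortho to two methoxy groups (2 heavy atoms each) and para to a large group.

In this assay the step from compound 3 to compound 4 is expected to be a 1.6-fold higher number from compound 3 to compound 4 (0.22 log units; within the scatter). This rests on one earlier instance only, the step of compound 1 to compound 2, which gave a 12-fold higher number from compound 1 to compound 2 (1.08 log units; beyond the scatter), and on the different surroundings of the entering group here, which weakens any direct carry-over. For compound 4 the estimate is 22000 nM, expected to lie between 7000 nM and 70000 nM.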

Compound 4, half-maximal inhibitory concentration: > 50000 nM
Compound 4: only a limit was reported; the forecaster's own chance of this, stated with the estimate: 15%; middle value at least 2.2-fold (0.35 log units) from the limit.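

In this assay, methoxy in place of hydrogen on an aromatic carbon again goes with weaker inhibition, with an at least 3.7-fold higher number from compound 3 to compound 4 (0.57 log units; beyond the scatter). Compound 4 gives > 50000 nM, which is a limit and not a number, so this step is a lower bound on the change. The two instances point the same way on two cores, which is a shared direction on very few cases, while carry-over of the size of the change cannot be read: the same change on two cores in this assay, a 12-fold higher number (1.08 log units; beyond the scatter) from compound 1 to compound 2 and an at least 3.7-fold higher number (0.57 log units; beyond the scatter) from compound 3 to compound 4; the limit leaves it open whether they differ

The compounds shown carry only hydrogen or methoxy on the two aryl groups, which leaves open whether the higher number belongs to methoxy itself or would follow from other groups in those places, such as fluoro, chloro, hydroxyl or an amine. Also open, from the compounds shown here alone, is how the 3,5-dimethoxyphenyl group behaves on the core of compound 1, with hydrogen in place of the methoxy on the aryl group of the sulfone, a pairing that could test the carry-over with measured numbers at both ends.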